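Oxazole five-substituent change: amide to methylsulfanyl

A few compounds are considered here, and "the series" means these few. Any claim that something is new, unique, unknown or untested is made for them only; others in the source may bear on it.

Three compounds of the series share a core that carries a phenyl-terminated chain on a ketone and a variable group on the five-membered ring. Compound 1 `COc1ccc(-c2cnc(C(=O)CCCCCCc3ccccc3)o2)cc1` gives 100 nM in an assay (Rattus norvegicus) for inhibition of Fatty-acid amide hydrolase 1 (Homo sapiens); a lower number here means a stronger inhibitor, a higher number a weaker inhibitor. Compound 2 `O=C(CCCCCCc1ccccc1)c1ncc(-c2ccc(O)cc2)o1` gives 140 nM in this assay, and a 1.4-fold higher number from compound 1 to compound 2 (0.15 log units; within the scatter). Compound 3 `O=C(CCCCCCc1ccccc1)c1ncc(C(=O)N2CCSCC2)o1` gives 10 nM in this assay, the lowest of the three numbers; it stands a 10-fold lower number from compound 1 to compound 3 (1.00 log units; beyond the scatter) and a 14-fold lower number from compound 2 to compound 3 (1.15 log units; beyond the scatter).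

Compound 4 `CSc1cnc(C(=O)CCCCCCc2ccccc2)o1` has not yet been measured. Its change from compound 3 is methylsulfanyl in place of (thiomorpholin-4-yl)carbonyl on an aromatic carbon. Going by the values given here, no measured step replaces the thiomorpholinylcarbonyl with a small group of this kind, so none bears directly. The two steps into compound 3 only show that the group on this ring carbon shifts the number clearly beyond the scatter in this assay, with the amide the lowest of three. Methylsulfanyl carries neither the ring nor the carbonyl of the leaving group, and the expectation is therefore a higher number for compound 4 than for compound 3, of a size between the steps from compound 1 and compound 2, with wide uncertainty because the direction for a small group is not established by any pair here.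

Compound 4 is estimated at 150 nM in this assay, within 30 nM to 800 nM, a step of a 15-fold higher number from compound 3 to compound 4 (1.18 log units; beyond the scatter).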

Compound 4, inhibition constant: 25 nM
Compound 4: middle estimate off by 6.0-fold (0.78 log units), on the high side; the measured number lies below the stated range.
By their numbers in this assay, from the lowest: compound 3; then compound 4; then compounds 1 and 2 (each within the scatter of the next).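

In this assay, methylsulfanyl, with 2 heavy atoms and no ring, stays close to the larger amide it replaces, at a 2.5-fold higher number from compound 3 to compound 4 (0.40 log units; beyond the scatter), a modest step beyond the scatter. The same small group also sits clearly under both aryl compounds, at a 5.6-fold lower number from compound 2 to compound 4 (0.75 log units; beyond the scatter) and a 4.0-fold lower number from compound 1 to compound 4 (0.60 log units; beyond the scatter), so among these four compounds, neither the six-membered ring nor the carbonyl of (thiomorpholin-4-yl)carbonyl is needed for a lower number than the 4-methoxyphenyl and 4-hydroxyphenyl compounds give at this aromatic carbon next to the ring oxygen. No measurement given here accounts for the order of the groups at this position.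

The compounds shown leave open whether the sulfur counts at this carbon, which methoxy or ethyl in place of methylsulfanyl would test, and whether it counts in the amide, which (morpholin-4-yl)carbonyl would test. On these data alone, all four compounds carry the same phenyl-terminated chain on the ketone, so it also remains open whether this order of groups would hold with a shorter chain.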